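This account rests on a few compounds, and the source may have more. Where it says the series, first, only, none or still open, it means among the compounds named here.

Working notes on a short series of benzamides bearing a carboxylic acid, all tested in an assay on HeLa cells for agonist activity at Bile acid receptor (Homo sapiens), read by a luciferase reporter; a lower number here means a smaller maximal response, a higher number a larger maximal response.

Compound 1 `O=C(O)c1cccc(NC(=O)c2ccc(OCc3ccccc3)cc2)c1` in this assay gives 20%. Compound 2 `O=C(O)c1cccc(NC(=O)c2ccc(Oc3ccccc3)cc2)c1` gives 35%. Compound 3 `CC(C)(C)c1ccc(C(=O)Nc2cccc(C(=O)O)c2)cc1` gives 21%. Among these three, compound 3 stands second highest; its nearest neighbour is compound 1, within the scatter, and its furthest is compound 2, beyond the scatter. For the measured compounds named here, the steps so far are a number 15 percentage points higher from compound 1 to compound 2 (beyond the scatter), a number 1 percentage points higher from compound 1 to compound 3 (within the scatter) and a number 14 percentage points lower from compound 2 to compound 3 (beyond the scatter); all three compounds vary only at the same aromatic carbon, and the whole spread of the series remains modest.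

Compound 4 `CN(C)c1ccc(C(=O)Nc2cccc(C(=O)O)c2)cc1` is the next compound to be measured. The change is dimethylamino in place of tert-butyl on an aromatic carbon. Going by the values given here, no measured step exchanges the tert-butyl for a dimethylamino, so no direct precedent exists. Among the compounds with values here, what bears on it is that every exchange at this position so far has moved the maximal response by at most a modest amount, and the exchange of benzyloxy for tert-butyl from compound 1 to compound 3 stayed within the scatter. A step of no more than modest size is therefore expected, in either direction, and most likely none beyond the scatter.

For compound 4 the maximal response in this assay is estimated at 23%, within a range of 10% to 38%. This estimate corresponds to an expected step of a number 2 percentage points higher from compound 3 to compound 4 (within the scatter).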

Compound 4, largest response reached (Emax), in percent of the reference or control that the assay uses: 19%
Beside the measured number, compound 4's estimate is 4 percentage points above it; the measured number falls inside the stated range.
By their numbers in this assay, from the lowest: compounds 4, 1 and 3 (each within the scatter of the next); then compound 2.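

In this assay, the exchange of tert-butyl for dimethylamino puts a nitrogen and one hydrogen-bond acceptor on this aromatic carbon, yet the step is a number 2 percentage points lower from compound 3 to compound 4 (within the scatter), so the maximal response does not distinguish these two groups. The dimethylamino compound also cannot be told apart from the benzyloxy compound, with a step of a number 1 percentage points lower from compound 1 to compound 4 (within the scatter), so three groups that differ in size and atom content, one of them carrying a ring, now share one level, while the step of a number 16 percentage points lower from compound 2 to compound 4 (beyond the scatter) confirms that compound 2, with its phenoxy group, stands alone above the other three. Nothing available bears on why phenoxy separates from the other groups at this aromatic carbon.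

The compounds shown leave open whether the higher response of compound 2 depends on the oxygen-linked phenyl ring directly on the core, and whether a group such as anilino, phenylthio or a chloro-substituted phenoxy would hold or extend it. They also leave open whether a small group such as methoxy, or a longer chain such as n-hexyl, would stay at the level of compounds 1, 3 and 4.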